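The compounds below may be only part of what the source reports. "The series", "measured", "known", "first", "only" and "open" are said of these compounds alone.

Of the compounds shown here, two have been measured so far in an ADME assay on microsomes from liver (Homo sapiens) for metabolic stability, read by HPLC, with a stated time of 10 min, tested at 3 uM; a higher number here means that more of the compound is left, a lower number that less of the compound is left. Compound 1 (`Cc1cc(Nc2nc(Cl)cn([C@H](C)C3CC3)c2=O)c(C)nc1OC(F)F`) gives 100%. Compound 2 (`COC[C@H](C1CC1)n1cc(Cl)nc(Nc2cc(C#N)c(OC(F)F)nc2C)c1=O`) gives 74%, the lower of the two numbers, and its gap to compound 1 lies beyond the usual scatter. Within the data shown here, no measured pair differs in only one place, so the data do not yet isolate the effect of any single change.

Compound 3 (`COC[C@@H](C1CC1)n1cc(Cl)nc(Nc2cc(C#N)c(OC(F)F)nc2C)c1=O`) is a close relative of compound 2: the two compounds have the same atoms and bonds and differ only in configuration as drawn: 1 of 1 stereo elements differ; a stereocentre at a saturated chain carbon is drawn S in compound 2 and R in compound 3. Nothing is added or removed, so the only question is what this change of configuration does to the read-out. The measured compounds contain no case of a configuration change on its own, which leaves no direct guide to its size or direction. The best starting point is therefore compound 2 at 74%, and no step beyond the scatter is expected. The expected size is small, given as a number 2 percentage points higher from compound 2 to compound 3 (within the scatter), although a larger move in either direction cannot be ruled out. In this assay, the estimated value for compound 3 is 76%, with an expected range of 55% to 96%.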

Compound 3, percent of the compound remaining: 78%
Estimate against measurement, compound 3: 2 percentage points below; low and high end bracket the measured number.
By their numbers in this assay, from the lowest: compounds 2 and 3 (each within the scatter of the next); then compound 1.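

Among these compounds, this pair gives the first comparison in the set that isolates a single change: in this assay it shows a number 4 percentage points higher from compound 2 to compound 3 (within the scatter) for the swap of the stereocentre at the saturated chain carbon from S to R. At this carbon, then, the configuration as drawn does not separate the two compounds by more than repeated measurements commonly would, so neither form can be called the better one in this read-out. The comparison is clean, since nothing else in the structures can account for what is seen between them: the fact that compounds 2 and 3 differ only in the configuration as drawn

Compound 1 differs from compound 2 and compound 3 in more than one place, so the data cannot say which of those differences goes with its number, and this one pair cannot say whether configuration at this carbon would matter as little on another core. From the compounds shown here alone, whether the same holds once an amine or a longer chain is attached at this stereocentre also stays open.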